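The compounds below may be only part of what the source reports. "The series", "measured", "known", "first", "only" and "open" are said of these compounds alone.

Compound 1, `CN(C)CC(=O)NCC(=O)N(C)c1ccc(Cl)cc1C(=O)c1ccccc1Cl`, in a functional assay on the whole organism with Mus musculus as the target, in the rotarod test (a higher number here means that more compound is needed for the effect, a lower number that less compound is needed), gives 26 mg/kg. Compound 2, `CC(C)C(=O)NCC(=O)N(C)c1ccc(Cl)cc1C(=O)c1ccccc1Cl`, in this assay gives only a limit, > 100 mg/kg. Compound 3, `CN(C(=O)CNC(=O)c1ccccc1)c1ccc(Cl)cc1C(=O)c1ccccc1Cl`, in this assay likewise gives only a limit, > 100 mg/kg.

Compound 3 therefore stands at the edge of what this assay reports, not at a number; the limit of > 100 mg/kg in this assay, at which 2 of the 3 values shown sit, marks where it sits together with compound 2. The measured steps of an at least 3.8-fold higher number from compound 1 to compound 2 (0.58 log units; beyond the scatter) and an at least 3.8-fold higher number from compound 1 to compound 3 (0.58 log units; beyond the scatter) both change the group on a carbonyl carbon of the shared core and both run in the same direction; the step that the two limits leave unreadable from compound 2 to compound 3 cannot be read, as both of its ends are limits.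

Compound 4, `CN(C(=O)CNC(=O)c1ccccc1)c1ccc(Cl)cc1C(=O)c1ccccc1`, differs from compound 3 elsewhere: hydrogen in place of chloro on an aromatic carbon. For the measured compounds named here, none of the measured steps touches this aromatic carbon, so no measured step bears directly on it. Going by the values given here, the only guide is that compound 3 already gives a limit, and a change of a single heavy atom on the far ring gives no reason to expect a move into the readable range. Compound 4 is therefore expected to stay near the limit, with an expected step that the limit leaves unreadable from compound 3 to compound 4. The estimate for compound 4 in this assay is 150 mg/kg, ranging from 60 mg/kg to 400 mg/kg.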

Compound 4, dose for half-maximal effect: > 100 mg/kg
Compound 4 ended at the assay's limit (the forecaster's own chance of this, stated with the estimate: 70%); the middle value does not contradict the limit.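

In this assay compound 4 gives > 100 mg/kg, which is a limit and not a number. Compound 3 also stands at a limit, so no step can be read between compound 3 and compound 4. The compounds shown leave open whether hydrogen in place of chloro on this aromatic carbon changes the dose needed in this assay at all.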